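Removing a Hydroxy Group on the Way to Compound 4

The source may report more compounds than this note shows. Statements on the series, on what has been measured and on what is new or still open speak of the compounds shown alone.

Three compounds built on one shared core have been examined in an assay on HEK293 cells for displacement of a labelled ligand from D(4) dopamine receptor (Homo sapiens), read by scintillation counting, with a stated time of 1 h; on this read-out lower numbers stand for stronger inhibition and higher numbers for weaker inhibition. Compound 1 `COc1ccccc1N1CCN(CC(O)CCn2cc(-c3ccc4ncccc4c3)nn2)CC1` gives only a limit of the assay in this assay, > 3000 nM, and no number. Compound 2 `OC(CCn1cc(-c2ccc(-c3ccccc3)cc2)nn1)CN1CCN(c2cccc(Cl)c2Cl)CC1` likewise gives only a limit in this assay, > 7000 nM. For compound 3 `OC(CCn1cc(-c2ccc3ncccc3c2)nn1)CN1CCN(c2cccc(Cl)c2Cl)CC1` this assay reports "not determined" (no result reported), so no number stands for it either. The two further values that accompany compound 3 are both limits, as the limit of > 3000 nM in this assay, at which 1 of the 3 values shown sits, and the limit of > 7000 nM in this assay, at which 1 of the 3 values shown sits, show. Nothing measured therefore places compound 3 on a scale of strong or weak inhibition.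

Compound 4 `Clc1cccc(N2CCN(CCCCn3cc(-c4ccc5ncccc5c4)nn3)CC2)c1Cl` differs from compound 3 in a single place: hydrogen in place of hydroxy on a saturated chain carbon bound to two saturated chain carbons. Among the compounds with values here, no pair of measured compounds that differ in just this way exists here, so no measured step tells how large an effect this change has in this assay or in which direction it runs. The two limits seen for compound 1 and compound 2 suggest that the shared core has not yet produced a measurable number, and the change to compound 4 carries no measured evidence that would move it clearly one way or the other beyond the usual scatter.

Compound 4 is expected to give about 3000 nM in this assay, with an estimated span from 150 nM to 20000 nM.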

Compound 4, inhibition constant: > 1000 nM
Compound 4: a limit, no number; the forecaster's own chance of this, stated with the estimate: 50%; the middle value lies beyond the limit too.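

In this assay compound 4 gives only a limit of the assay, > 1000 nM, and no number. Within the data shown here, compound 3 has no number either, so the change from compound 3 to compound 4 yields no step that can be read. The compounds shown leave open how large an effect hydrogen in place of hydroxy has in this assay, and in which direction it runs.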